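Swapping a Remote Aryl Group: Expected Acidity of Compound 3

The source may report more compounds than this note shows. Statements on the series, on what has been measured and on what is new or still open speak of the compounds shown alone.

Compound 1, `Fc1ccc(-c2ccc3c(NCCCNCc4ccco4)ccnc3c2)cc1`: 9.47
Compound 2, `COc1cccc(Oc2ccc3c(NCCCNCc4ccco4)ccnc3c2)c1`: 9.28

Both compounds were measured in a physicochemical assay for acid dissociation. Of the two numbers, compound 2 has the lowest value, and its nearest neighbour is compound 1, with the step of a number 0.19 log units lower from compound 1 to compound 2 (within the scatter) separating them; that step lies within the scatter, so the two compounds cannot be told apart on this read-out.

Compound 3, `N#Cc1ccc(Cc2ccc3c(NCCCNCc4ccco4)ccnc3c2)cc1`, has not yet been measured. It differs from compound 2 at a single place: 4-cyanobenzyl in place of 3-methoxyphenoxy on an aromatic carbon.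

Going by the values given here, only one measured step bears on this change, the one from compound 1 to compound 2, which also exchanged one aryl group for another on the same aromatic carbon of the shared core and moved the number by a number 0.19 log units lower from compound 1 to compound 2 (within the scatter). Among the compounds with values here, with that single step as the only guide, no step beyond the scatter is expected here either. Compound 3 is therefore estimated at 9.3, with a range from 8.9 to 9.7, which means an expected step of a number 0.02 log units higher from compound 2 to compound 3 (within the scatter).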

Compound 3, acid dissociation constant: 9.47
The estimate for compound 3 lay 0.17 log units below the measured number; the measured number falls inside the stated range.
By their numbers in this assay, from the lowest: compounds 2, 1 and 3 (each within the scatter of the next).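

In this assay, replacing 3-methoxyphenoxy with 4-cyanobenzyl on this aromatic carbon gives a number 0.19 log units higher from compound 2 to compound 3 (within the scatter) and replacing 4-fluorophenyl with the same group gives no change at the digits printed from compound 1 to compound 3 (within the scatter) as the second comparison, so all three compounds remain indistinguishable on this read-out. The outer ring is now joined to the shared core by a direct bond, an oxygen or a carbon, and it carries fluoro, methoxy or nitrile, yet none of the steps among these compounds leaves the scatter. Nothing available explains why the number stays put across these exchanges, and no further data bear on the result.

As far as these compounds go, all three groups at this position are uncharged and contain one six-membered aromatic ring of carbon only, so it remains open whether an amine, a carboxylic acid or a simple methyl group at the same carbon would produce a step beyond the scatter. The chain elsewhere on the shared core is identical in all three compounds, so these results also leave open what a shorter or longer chain would do to the number.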